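The source may report more compounds than this note shows. Statements on the series, on what has been measured and on what is new or still open speak of the compounds shown alone.

Measured so far in a functional assay on HCT-15 cells (Homo sapiens) for inhibition; on this read-out lower numbers stand for stronger inhibition and higher numbers for weaker inhibition:
Compound 1, `Oc1cccc(-c2cc(-c3ccccc3F)cc(-c3cccc(O)c3)n2)c1`, gives 5300 nM.
Compound 2, `Oc1cccc(-c2cc(-c3ccc(F)cc3)cc(-c3cccc(O)c3)n2)c1`, gives 6310 nM.
Compound 3, `Oc1cccc(-c2cc(-c3cccc(C(F)(F)F)c3)cc(-c3cccc(O)c3)n2)c1`, gives 13600 nM.

Compound 3 stands highest of the three numbers, both of its steps from the other compounds lying beyond the scatter: a 2.6-fold higher number from compound 1 to compound 3 (0.41 log units; beyond the scatter) and a 2.2-fold higher number from compound 2 to compound 3 (0.33 log units; beyond the scatter).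

Compound 4, `Oc1cccc(-c2cc(-c3ccc(C(F)(F)F)cc3)cc(-c3cccc(O)c3)n2)c1`, is not yet measured. It differs from compound 3 in one place: 4-(trifluoromethyl)phenyl in place of 3-(trifluoromethyl)phenyl on an aromatic carbon. Within the data shown here, the only measured step of a comparable kind is that between the two fluorophenyl compounds, a 1.2-fold higher number from compound 1 to compound 2 (0.08 log units; within the scatter), which lies within the scatter. Among the measured compounds shown here, no step between a 3-(trifluoromethyl)phenyl and a 4-(trifluoromethyl)phenyl compound has been measured. On that basis the expected change in this assay is a 1.1-fold lower number from compound 3 to compound 4 (0.04 log units; within the scatter), with no movement beyond the scatter anticipated. Compound 4 is accordingly estimated at 12500 nM, within 6000 nM to 28000 nM.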

Compound 4, half-maximal inhibitory concentration: > 50000 nM
Compound 4: no number, only a limit; the forecaster's own chance of this, stated with the estimate: 5%; middle value at least 4.0-fold (0.60 log units) from the limit.
By their numbers in this assay, from the lowest: compounds 1 and 2 (each within the scatter of the next); then compound 3. At a limit, above all of these: compound 4.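

In this assay compound 4 reads only as a limit, not a number: the limit of > 50000 nM in this assay, at which 1 of the 4 values shown sits. Placing 4-(trifluoromethyl)phenyl rather than 3-(trifluoromethyl)phenyl opposite the ring nitrogen gives an at least 3.6-fold higher number from compound 3 to compound 4 (0.56 log units; beyond the scatter), so the place of the trifluoromethyl on this phenyl matters, which the fluorophenyl pair, with a 1.2-fold higher number from compound 1 to compound 2 (0.08 log units; within the scatter), did not show. The fluorophenyl compounds also sit well apart from it, with an at least 7.9-fold higher number from compound 2 to compound 4 (0.89 log units; beyond the scatter) and an at least 9.4-fold higher number from compound 1 to compound 4 (0.97 log units; beyond the scatter).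

How far compound 4 lies past its limit stays open, and the series gives no reason for the step. Also open, going by these compounds, is how 4-aminophenyl or 4-carboxyphenyl would read in this place.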